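A few compounds are considered here, and "the series" means these few. Any claim that something is new, unique, unknown or untested is made for them only; others in the source may bear on it.

In a functional assay on HCT-116 cells (Homo sapiens) for cytotoxicity, read by MTT assay, with a stated time of 72 h (a higher number here means a weaker inhibitor, a lower number a stronger inhibitor), compound 1 `Nc1ccccc1NC(=O)c1ccc(CNC(=O)c2cc3cccnc3[nH]2)cc1` reads 10000 nM and compound 2 `Nc1ccccc1NC(=O)c1ccc(CNC(=O)c2cc3cnccc3[nH]2)cc1` reads 4000 nM as the lower of the two numbers. Compound 3 `Nc1ccccc1NC(=O)c1ccc(CNC(=O)c2ccc3cncn3c2)cc1` has the same atoms as compound 2, joined differently, and the change falls on a carbonyl carbon (a group of 9 heavy atoms (7 carbon, 2 nitrogen; one five-membered aromatic ring with 2 hetero atoms, one six-membered aromatic ring with 1 hetero atom) in place of a group of 9 heavy atoms (7 carbon, 2 nitrogen; one five-membered aromatic ring with 1 hetero atom, one six-membered aromatic ring with 1 hetero atom), on a carbonyl carbon). For the measured compounds named here, the one measured step that bears on this is modest (a 2.5-fold lower number from compound 1 to compound 2 (0.40 log units; beyond the scatter)), so no much larger step is expected in this assay, and perhaps none beyond the scatter, with the direction left open. The estimated step is small (a 1.3-fold higher number from compound 2 to compound 3 (0.10 log units; within the scatter)). Compound 3 is estimated at (5000 nM), with an expected range of (1500 nM to 15000 nM).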

Compound 3, half-maximal inhibitory concentration: 7400 nM
Estimate against measurement, compound 3: 1.5-fold (0.17 log units) below; measured number inside the range.
By their numbers in this assay, from the lowest: compounds 2, 3 and 1 (each within the scatter of the next, the first and the last beyond it).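

In this assay the group with 2 hetero atoms in its five-membered ring, with 0 hydrogen-bond donors against 1 in the group it replaces, gives a 1.9-fold higher number from compound 2 to compound 3 (0.27 log units; within the scatter) and a 1.4-fold lower number from compound 1 to compound 3 (0.13 log units; within the scatter) and so stays within the scatter of both earlier compounds. On this carbonyl carbon it therefore cannot be told apart from either earlier group, although those two lie beyond the scatter of each other. No available evidence accounts for this result.

Open, as far as these compounds go, is how a group of another kind on this carbonyl carbon, such as a simple phenyl ring or a piperidine ring, would read. Also open is whether any such group would give a step larger than those seen among these three compounds.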